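The source may report more compounds than this note shows. Statements on the series, on what has been measured and on what is new or still open speak of the compounds shown alone.

Measured so far:
compound 1, `CC1=C(C(=O)OC2CCCC2)C(c2ccco2)NC(=O)N1`: 577 nM
compound 2, `CC1=C(C(=O)OC2CCCC2)C(c2ccoc2)NC(=O)N1`: 1010 nM

In an assay on membranes from HEK293 cells for displacement of a labelled ligand from adenosine receptor A2b (Homo sapiens), read by scintillation counting, with a stated time of 30 min (a lower number here means a stronger inhibitor, a higher number a weaker inhibitor), compound 2 gives 1010 nM, the higher of the two numbers; its nearest neighbour is compound 1 with 577 nM, and the gap between them lies within the scatter. Compound 3, `CC1=C(C(=O)OC2CCCC2)C(c2ccsc2)NC(=O)N1`, has not yet been measured. It differs from compound 2 in one place: thiophen-3-yl in place of furan-3-yl on a saturated ring carbon. Going by the values given here, no measured step exchanges oxygen for sulfur in this five-membered ring, so there is no direct guide. Among the compounds with values here, the only step available, a 1.8-fold higher number from compound 1 to compound 2 (0.24 log units; within the scatter), concerns a different change at the same saturated ring carbon and stays within the scatter, giving no sign that this position shifts the number strongly. A step within the scatter is therefore expected, a 1.3-fold lower number from compound 2 to compound 3 (0.10 log units; within the scatter). Compound 3 is estimated at 800 nM, with a range of 300 nM to 2500 nM.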

Compound 3, inhibition constant: 659 nM
Compound 3: middle estimate off by 1.2-fold (0.08 log units), on the high side; measured number inside the range.
By their numbers in this assay, from the lowest: compounds 1, 3 and 2 (each within the scatter of the next).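

In this assay, exchanging the ring oxygen for sulfur gives a 1.5-fold lower number from compound 2 to compound 3 (0.19 log units; within the scatter), and comparing thiophen-3-yl with furan-2-yl gives a 1.1-fold higher number from compound 1 to compound 3 (0.06 log units; within the scatter); both steps lie within the scatter. With the earlier furan step, this means that the three five-membered aromatic rings shown on this saturated ring carbon cannot be told apart in this measurement, whether the hetero atom is oxygen or sulfur. No separate measurement is available to explain this result.

From the compounds shown here alone, it remains open whether any group on this carbon can shift the number beyond the scatter, for example a phenyl ring, a cyclohexyl group or an aminomethyl group. Going by these compounds, the methyl group is the same in all three compounds, so the effect of a longer chain in its place also remains open.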